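Spirocyclic amide series: azole exchange at the pyridine amide

A few compounds are considered here, and "the series" means these few. Any claim that something is new, unique, unknown or untested is made for them only; others in the source may bear on it.

Measured compounds:
- compound 1 `Cc1ccnc(NC[C@@H]2CC3(CC3)CN2C(=O)c2nc(C)sc2-c2ccccc2)n1`: 6.1
- compound 2 `Cc1ccc(-n2nccn2)c(C(=O)N2CC3(CC3)C[C@H]2CNc2ccc(Cl)cn2)c1`: 8.1
- compound 3 `Cc1ccc(-c2nccs2)c(C(=O)N2CC3(CC3)C[C@H]2CNc2ccc(C(F)(F)F)cn2)n1`: 8.6

In a functional assay on CHO cells for antagonist activity at Orexin/Hypocretin receptor type 1 (Homo sapiens), read by FLIPR and calcium flux (a lower number here means a less potent compound, a higher number a more potent compound, by a factor of ten per unit of this negative logarithm), compound 3 gives 8.6, the highest of the three numbers. Its nearest neighbour on the numbers is compound 2, whose 8.1 lies lower by a gap beyond the scatter; compound 1 sits furthest away, its 6.1 lower by a gap that is also beyond the scatter.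

Compound 4 `Cc1cnn(-c2ccc(C)nc2C(=O)N2CC3(CC3)C[C@H]2CNc2ccc(C(F)(F)F)cn2)c1` keeps the shared core of compound 3 and its trifluoromethyl-substituted pyridine amine, and alters only the azole on the amide-bearing ring: 4-methyl-1H-pyrazol-1-yl in place of 1,3-thiazol-2-yl on an aromatic carbon. Among the compounds with values here, no measured pair in this set isolates this one change, so the expected step from compound 3 to compound 4 rests on the ring exchange itself. Both groups are five-membered aromatic rings with two hetero atoms and two hydrogen-bond acceptors, so no step beyond the scatter is anticipated; if any, a slight loss. Compound 4 is expected to give 8.4, between 7.7 and 9, a step of a number 0.20 log units lower from compound 3 to compound 4 (within the scatter) that is estimated to stay within the usual scatter.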

Compound 4, negative logarithm of the antagonist equilibrium constant: 8.9
For compound 4 the middle estimate is 0.50 log units below the measured one; low and high end bracket the measured number.
By their numbers in this assay, from the lowest: compound 1; then compound 2; then compounds 3 and 4 (each within the scatter of the next).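

In this assay, exchanging 1,3-thiazol-2-yl for 4-methyl-1H-pyrazol-1-yl on this aromatic carbon, ortho to a large group, gives a number 0.30 log units higher from compound 3 to compound 4 (within the scatter), so at this place the two azoles cannot be told apart in this read-out, even though the sulfur is lost and one heavy atom is added. Within the data shown here, compound 1 and compound 2 offered no comparison in one place, so this is the only pair that isolates the azole itself. Nothing available bears on why the two rings read alike.

The compounds shown leave open what the plain 1H-pyrazol-1-yl, without its methyl group, would give at this place. Also open, on these data alone, is whether a non-ring group, such as an amine or a carboxylic acid, would hold the number there.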